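Swapping methoxy for nitro in a thiourea sulfonamide pair

The source may report more compounds than this note shows. Statements on the series, on what has been measured and on what is new or still open speak of the compounds shown alone.

Measured compounds:
- compound 1, `COc1cccc(NC(=S)NCCNS(=O)(=O)c2ccc(-c3ccccc3Oc3ccc([N+](=O)[O-])cc3)s2)c1`: > 20000 nM
- compound 2, `COc1ccc(NC(=S)NCCNS(=O)(=O)c2sccc2-c2ccc(C)cc2Oc2ccc(O)c(O)c2)cc1`: > 20000 nM

Compound 1 was tested in an ADME assay on HEK-293T cells (Homo sapiens) for cytotoxicity, read by CCK-8 assay, with a stated time of 48 h (on this read-out higher numbers stand for weaker inhibition and lower numbers for stronger inhibition), and gives only a limit of the assay, namely > 20000 nM. Compound 2 likewise gives only a limit in this assay, reporting > 20000 nM. Compound 2 therefore stands at the edge of what the assay can resolve, and it shares that position with compound 1, since (the limit of > 20000 nM in this assay, at which 2 of the 2 values shown sit). Going by the values given here, no pair among the measured compounds differs in a single place, so no measured step on cytotoxicity is available.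

The unmeasured compound 3, `Cc1ccc(-c2ccsc2S(=O)(=O)NCCNC(=S)Nc2ccc([N+](=O)[O-])cc2)c(Oc2ccc(O)c(O)c2)c1`, is reached from compound 2 by one change: nitro in place of methoxy on an aromatic carbon. The difference lies on an aromatic carbon of a six-membered aromatic ring of carbon only, para to a large group.

With both measured values sitting at the limit, the step from compound 2 to compound 3 in this assay is expected to show no change beyond the scatter, and most likely another limit, as a step that the limit leaves unreadable from compound 2 to compound 3. Compound 3 is estimated at 25000 nM, with a range of 12000 nM to 60000 nM.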

Compound 3, half-maximal inhibitory concentration: 8200 nM
Estimate against measurement, compound 3: 3.0-fold (0.48 log units) above; the measured number lies below the stated range.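

In this assay, replacing methoxy with nitro on an aromatic carbon para to a large group gives an at least 2.4-fold lower number from compound 2 to compound 3 (0.38 log units; beyond the scatter), so the group at this position can affect the cytotoxicity read-out on these cells. Going by these compounds alone, compound 3, at 8200 nM, is the first compound here to give a number inside the range of the assay. The earlier compounds shown here established only that a limit could be reached. The size of the step is open at one end because compound 2 gives only a limit, so the true gap could be larger than the printed one: the limit of > 20000 nM in this assay, at which 2 of the 3 values shown sit.

The compounds shown leave open whether this shift belongs to nitro in particular or would also appear with an amine, a nitrile or a carboxylic acid on the same aromatic carbon. They also leave open whether the same exchange would move the number in this assay on a different core, since this single pair is the only one that differs in one place, and one pair sets no general pattern.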